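A Sulfonyl Side Chain Swap on a Shared Core

The source may hold more compounds than are shown below. What is called first, only, known or untested is meant among the compounds shown, and "the series" means these compounds.

Compound 1, `CC(O)CCCC12CCC(c3nnc(-c4ccccc4C(F)(F)F)n3C)(CC1)CC2`, in an assay on CHO-K1 cells for inhibition of 11-beta-hydroxysteroid dehydrogenase type 2 (Mus musculus), read by scintillation proximity assay (on this read-out lower numbers stand for stronger inhibition and higher numbers for weaker inhibition), gives > 4000 nM, which is a limit of the assay rather than a number.
Compound 2, `Cn1c(-c2ccccc2C(F)(F)F)nnc1C12CCC(COc3ccc(S(C)(=O)=O)cc3)(CC1)CC2`, gives > 4000 nM, again only a limit.
Compound 3, `CC(F)CCCC12CCC(c3nnc(-c4ccccc4C(F)(F)F)n3C)(CC1)CC2`, gives > 4000 nM, once more a limit.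

Compound 2 therefore stands at the limit, and it does not stand alone there: the limit of > 4000 nM in this assay, at which 3 of the 3 values shown sit. The three measured steps carry no readable size for the same reason. The change from compound 1 to compound 2 gave a step that the two limits leave unreadable from compound 1 to compound 2, the change from compound 2 to compound 3 gave a step that the two limits leave unreadable from compound 2 to compound 3, and the change from compound 1 to compound 3 gave a step that the two limits leave unreadable from compound 1 to compound 3.

Compound 4 is `Cn1c(-c2ccccc2C(F)(F)F)nnc1C12CCC(CCS(=O)(=O)C(C)(C)C)(CC1)CC2`. The difference from compound 2 is ((tert-butyl)sulfonyl)methyl in place of 4-(methylsulfonyl)phenoxy on a saturated chain carbon bound to a saturated ring carbon. The step from compound 1 to compound 2 and the step from compound 2 to compound 3 both concern the same chain carbon and bear on this change, but neither gives a size, so no direction can be read for compound 4.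

With every measured value at the limit, compound 4 is expected to sit there too, and a step that the limit leaves unreadable from compound 2 to compound 4 is the estimate. Compound 4 is estimated at 5000 nM, with a range from 1000 nM to 30000 nM.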

Compound 4, half-maximal inhibitory concentration: > 4000 nM
Compound 4 was reported as a limit; the forecaster's own chance of this, stated with the estimate: 75%; the middle value lies beyond the limit too.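

In this assay compound 4 gives > 4000 nM, a limit and not a number, so no step from compound 1, compound 2 or compound 3 to compound 4 can be read: the limit of > 4000 nM in this assay, at which 4 of the 4 values shown sit.

The compounds shown leave open how strongly any of the four inhibits, and whether these side chain swaps change inhibition at all.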